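The source may hold more compounds than are shown below. What is called first, only, known or untested is meant among the compounds shown, and "the series" means these compounds.

Compound 2, `O=S(=O)(NCCCNCc1ccc(Cl)c(C(F)(F)F)c1)c1cc(C(F)(F)F)cc(C(F)(F)F)c1`, gives 7400 nM in a functional assay on MIA PaCa-2 cells (Homo sapiens) for inhibition, read by MTT assay, with a stated time of 72 h (a lower number here means a stronger inhibitor of growth, a higher number a weaker inhibitor of growth), the highest of the two numbers in hand. Going by the values given here, its only neighbour, compound 1, `O=S(=O)(NCCCNCc1ccc(Cl)c(Cl)c1)c1cc(C(F)(F)F)cc(C(F)(F)F)c1`, gives 2700 nM in this assay, and the single measured step, a 2.7-fold higher number from compound 1 to compound 2 (0.44 log units; beyond the scatter), is the whole record of how this series answers a change on the aromatic ring at the amine end.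

Compound 3, `O=S(=O)(NCCCNCC1COc2ccccc2O1)c1cc(C(F)(F)F)cc(C(F)(F)F)c1`, has not been measured. Compared with compound 2 it carries 2,3-dihydro-1,4-benzodioxin-2-yl in place of 4-chloro-3-(trifluoromethyl)phenyl on a saturated chain carbon bound to an amine nitrogen. Among the compounds with values here, the one measured step touches the same ring, but it swapped a single substituent; here the entire substituted aromatic ring is replaced by a fused bicyclic group with two acceptors. Within the data shown here, no measured step therefore speaks directly to this change, and any expectation rests on compound 2 alone. Given that compound 2 already sits at 7400 nM and that the one known step was only modest, the expected movement for compound 3 is an uncertain step, a 1.5-fold higher number from compound 2 to compound 3 (0.17 log units; within the scatter), towards a somewhat higher number. Compound 3 is therefore estimated at 11000 nM in this assay, within a range from 3000 nM to 40000 nM.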

Compound 3, concentration for 50% growth inhibition: 2600 nM
Compound 3: middle estimate off by 4.2-fold (0.63 log units), on the high side, outside the stated range (below it).
By their numbers in this assay, from the lowest: compounds 3 and 1 (each within the scatter of the next); then compound 2.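

The result shows that a halogen-bearing phenyl group is not needed on a saturated chain carbon bound to an amine nitrogen to reach the lower numbers seen so far in this assay. Putting 2,3-dihydro-1,4-benzodioxin-2-yl in place of 4-chloro-3-(trifluoromethyl)phenyl gives a 2.8-fold lower number from compound 2 to compound 3 (0.45 log units; beyond the scatter), whereas the same group in place of 3,4-dichlorophenyl gives a 1.0-fold lower number from compound 1 to compound 3 (0.02 log units; within the scatter), so a group with no chloro or trifluoromethyl and with 2 hydrogen-bond acceptors matches the dichlorinated compound and leaves compound 2 as the one apart from the other two. Nothing available explains why this replacement is accepted or why compound 2 stands apart.

The three compounds leave open whether the two ring oxygens of the new group matter or whether the fused bicyclic shape alone is enough, a question that a 1,2,3,4-tetrahydronaphthalen-2-yl group or a plain unsubstituted phenyl at the same place would address. They also leave open whether any group here, such as a pyridine ring or a longer chain ending in a phenyl, could move the number beyond the level shared by compound 1 and compound 3.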